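Removing a chain chloro and tolerance in liver cells

A few compounds are considered here, and "the series" means these few. Any claim that something is new, unique, unknown or untested is made for them only; others in the source may bear on it.

Compound 1 `ClCCCSc1nnc(COc2ccc(Cl)cc2Cl)o1`: > 50000 nM, a limit of a functional assay on HepG2 cells (Homo sapiens) for cytotoxicity, with a stated time of 5 days (a higher number here means that more compound is tolerated, a lower number that less compound is tolerated), rather than a number.
Compound 2 `CCCSc1nnc(COc2ccc(Cl)cc2Cl)o1`: 19300 nM.
Compound 3 `O=[N+]([O-])c1cccc(OCc2nnc(SCCCCl)o2)c1`: > 50000 nM, again only a limit of this assay.

Compound 1 and compound 2 differ by hydrogen in place of chloro on a saturated chain carbon, three bonds along the chain from a sulfur, and this change brings an at least 2.5-fold lower number from compound 1 to compound 2 (0.41 log units; beyond the scatter). Compound 4 `CCCSc1nnc(COc2cccc([N+](=O)[O-])c2)o1` is related to compound 3 by hydrogen in place of chloro on a saturated chain carbon, three bonds along the chain from a sulfur, the same change in the same place. The difference between the core of compound 1 and the core of compound 3 is not broken down here. The size of the measured step is known only as a bound because of the limit of > 50000 nM in this assay, at which 2 of the 3 values shown sit, so the true drop from compound 1 to compound 2 may be larger than it reads. Given that, a step of at least comparable size is expected for the new pair: an at least 2.0-fold lower number from compound 3 to compound 4 (0.30 log units; that floor lies within the scatter). Compound 4 is therefore estimated to give 25000 nM in this assay, likely between 8000 nM and 60000 nM, with a real chance that only a limit is reported again.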

Compound 4, half-maximal cytotoxic concentration: > 50000 nM
Compound 4 ended at the assay's limit (the forecaster's own chance of this, stated with the estimate: 35%); middle value at least 2.0-fold (0.30 log units) from the limit.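

Within the data shown here, compound 3 and compound 4 both stop at a limit in this assay, so no step between them can be read, because neither gives an actual number: the limit of > 50000 nM in this assay, at which 3 of the 4 values shown sit.

Still open, going by these compounds, is whether hydrogen in place of chloro lowers the number on the core of compound 3, as it does on the core of compound 1.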